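Methoxy in Place of Hydrogen: From Compound 2 to Compound 3

A few compounds are considered here, and "the series" means these few. Any claim that something is new, unique, unknown or untested is made for them only; others in the source may bear on it.

Compound 1, `Cc1[nH]c2ccccc2c1C1CC(c2ccncc2)=NO1`, gives 17300 nM in a functional assay on CWR22R cells (Homo sapiens) for inhibition, read by MTT assay, with a stated time of 48 h; a lower number here means a stronger inhibitor, a higher number a weaker inhibitor.
Compound 2, `Clc1ccc(Cn2cc(C3CC(c4ccncc4)=NO3)c3ccccc32)cc1`, gives 9600 nM in this assay.

For the measured compounds named here, compound 2 holds the lowest of the two numbers in this assay; its only neighbour is compound 1, whose number lies within the scatter, so no order between the two can be claimed. Compound 3, `COc1ccc2c(c1)c(C1CC(c3ccncc3)=NO1)cn2Cc1ccc(Cl)cc1`, differs from compound 2 by methoxy in place of hydrogen on an aromatic carbon. Going by the values given here, no measured pair shows this change, so its effect is unknown, and a step no larger than the scatter is expected in either direction. Compound 3 is therefore estimated at 8000 nM, with a range from 3000 nM to 25000 nM. The expected step of a 1.2-fold lower number from compound 2 to compound 3 (0.08 log units; within the scatter) stays inside the scatter.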

Compound 3, half-maximal inhibitory concentration: 10600 nM
Compound 3: the middle estimate sits 1.3-fold (0.12 log units) below what was measured, within the range that was stated.
By their numbers in this assay, from the lowest: compounds 2, 3 and 1 (each within the scatter of the next).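

In this assay, this first measured pair for the change gives a 1.1-fold higher number from compound 2 to compound 3 (0.04 log units; within the scatter). Methoxy in place of hydrogen on this aromatic carbon, meta to a fused ring and para to a fused ring, therefore leaves the number indistinguishable from that of compound 2. Nothing measured bears on why this is so.

As far as these compounds go, whether an amine, a carboxylic acid or a longer chain on this carbon would also leave the number within the scatter stays open. So does whether methoxy on the other carbons of this ring would do the same.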